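The compounds below may be only part of what the source reports. "The series", "measured", "known", "first", "only" and "open" are said of these compounds alone.

Compound 1 `CCCCn1c(SCc2cc([N+](=O)[O-])ccc2OC)nc2cc(NC(=O)NC(C)(C)C)ccc21`: in an assay on isolated protein for inhibition of Gonadotropin-releasing hormone receptor (Rattus norvegicus) (a higher number here means a weaker inhibitor, a lower number a stronger inhibitor), compound 1 gives 330 nM.
Compound 2 `CCCn1c(SCc2cc([N+](=O)[O-])ccc2OC)nc2cc(NC(=O)NC(C)(C)C)cc(C(=O)N(C)C)c21`: in this assay compound 2 gives 200 nM.

Of the compounds shown here, two have been measured so far, and they share a common core carrying a tert-butylurea and a nitro-methoxybenzyl thioether. Compound 2 adds a dimethylcarbamoyl group to that core and shows the lower of the two numbers in this assay, but its gap to compound 1 lies within the usual scatter of such measurements, so the two cannot be ranked against each other.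

Compound 3 `CCCn1c(SCc2cc([N+](=O)[O-])ccc2OC)nc2cc(NC(=O)NC(C)(C)C)cc(C(=O)NCc3ccccc3)c21` keeps everything in compound 2 except one group: benzylamino in place of dimethylamino on a carbonyl carbon. Among the compounds with values here, no pair of measured compounds shows what this kind of swap does here, so there is no measured step to lean on. The expected outcome is a change of modest size, possibly no larger than the scatter, with the direction uncertain. Starting from compound 2, the estimated step is a 1.3-fold lower number from compound 2 to compound 3 (0.12 log units; within the scatter). Compound 3 is expected to give 150 nM in this assay, with a plausible range from 50 nM to 500 nM.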

Compound 3, half-maximal inhibitory concentration: 130 nM
Compound 3: the middle estimate sits 1.2-fold (0.06 log units) above what was measured; the measured number falls inside the stated range.
By their numbers in this assay, from the lowest: compounds 3, 2 and 1 (each within the scatter of the next, the first and the last beyond it).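

Within the data shown here, this is the first measured swap on a carbonyl carbon whose other neighbour is an aromatic carbon: in this assay benzylamino in place of dimethylamino gives a 1.5-fold lower number from compound 2 to compound 3 (0.19 log units; within the scatter) for this pair. The group that enters has 8 heavy atoms against 3 for the one that leaves, and it brings a six-membered aromatic ring and a hydrogen-bond donor, yet the two compounds cannot be told apart in this measurement, so this place accepts a much larger amine portion on the carbonyl without a change that can be read. No measured information is available that could explain this result.

The swap adds the ring and the amide hydrogen together, so a group such as N-methylbenzylamino, which keeps the ring but has no amide hydrogen, would be needed to separate the two. On these data alone, it also remains open whether a quite different group on this carbon, such as a hydroxyl that turns the amide into a carboxylic acid, or a longer chain between the amide nitrogen and the ring, would move the number beyond the scatter.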